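The compounds below may be only part of what the source reports. "The series", "measured", "known", "first", "only" and "open" are said of these compounds alone.

Measured compounds:

Compound 1 `C/C(=C\CC/C(C)=C/CC[C@@H]1[C@@]2(C)CCC(=O)C(C)(C)[C@H]2CC[C@@]1(C)O)CC/C=C(\C)C(=O)OCc1cn(-c2ccccc2C(F)(F)F)nn1` — in a functional assay on DU-145 cells (Homo sapiens) for antiproliferative activity, read by MTT assay, with a stated time of 48 h (a higher number here means a weaker inhibitor, a lower number a stronger inhibitor), compound 1 gives > 150000 nM, which is a limit of the assay and not a number.
Compound 2 `C/C(=C\CC/C(C)=C/CC[C@@H]1[C@@]2(C)CCC(=O)C(C)(C)[C@H]2CC[C@@]1(C)O)CC/C=C(\C)C(=O)OCc1cn(-c2ccccc2[N+](=O)[O-])nn1` — in this assay compound 2 gives > 150000 nM, again a limit of the assay.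
Compound 3 `COc1cccc(-n2cc(COC(=O)/C(C)=C/CC/C(C)=C/CC/C(C)=C/CC[C@@H]3[C@@]4(C)CCC(=O)C(C)(C)[C@H]4CC[C@@]3(C)O)nn2)c1` — in this assay compound 3 gives > 150000 nM, also a limit of the assay.

Compound 1 therefore stands only at a limit in this assay, with no number of its own, and the two other values shown are limits as well. The step from compound 1 to compound 2 is a step that the two limits leave unreadable from compound 1 to compound 2, and the step from compound 1 to compound 3 is a step that the two limits leave unreadable from compound 1 to compound 3; neither can be read in size, since (the limit of > 150000 nM in this assay, at which 3 of the 3 values shown sit).

Compound 4 `C/C(=C\CC/C(C)=C/CC[C@@H]1[C@@]2(C)CCC(=O)C(C)(C)[C@H]2CC[C@@]1(C)O)CC/C=C(\C)C(=O)OCc1cn(-c2ccc(C(C)(C)C)cc2)nn1` differs from compound 1 in one place: 4-(tert-butyl)phenyl in place of 2-(trifluoromethyl)phenyl on an aromatic nitrogen. The change sits at the same position as the changes already measured, and every one of those left the value at the limit. Among the compounds with values here, no measured step gives a readable size, so no shift beyond the scatter can be expected in either direction, and the most likely outcome is that compound 4 also stops at the limit.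

Compound 4 is estimated at 150000 nM in this assay, in a range from 60000 nM to 400000 nM. The expected step from compound 1 to compound 4 is a number no higher from compound 1 to compound 4 (the limit leaves the size open).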

Compound 4, half-maximal inhibitory concentration: > 150000 nM
Compound 4: a limit, no number (the forecaster's own chance of this, stated with the estimate: 75%); the middle value sits exactly at the limit.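

Compound 4 also stops at a limit of the assay and not at a number, so its steps from compound 1, compound 2 and compound 3 cannot be read in this assay: the limit of > 150000 nM in this assay, at which 4 of the 4 values shown sit.

The compounds shown leave open how far apart these four lie in this assay, and whether any group on that aromatic nitrogen changes the result at all.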